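Cyano in place of phenyl: cytotoxicity outlook for compound 4

The compounds below may be only part of what the source reports. "The series", "measured", "known", "first", "only" and "open" are said of these compounds alone.

Compound 1 `COC(=O)c1ccc(NCc2cncn2Cc2ccc(-c3ccccc3)cc2)cc1-c1ccccc1` is the reference point of this set. In a toxicity assay on NIH3T3 cells (Mus musculus) for cytotoxicity, read by resazurin assay (a higher number here means that more compound is needed for the effect, a lower number that less compound is needed), compound 1 gives > 1000 nM, which is a limit of the assay rather than a measured number. Compound 2 `CCCC(=O)c1ccc(NCc2cncn2Cc2ccc(-c3ccccc3)cc2)cc1-c1ccccc1` has propyl in place of methoxy on a carbonyl carbon. In this assay compound 2 gives > 10000 nM, again only a limit. Compound 3 `COc1ccc(NCc2cncn2Cc2ccc(-c3ccccc3)cc2)cc1-c1ccccc1` has methoxy in place of methoxycarbonyl on an aromatic carbon. In this assay compound 3 gives > 1000 nM, also a limit. Accordingly the measured steps are a step that the two limits leave unreadable from compound 1 to compound 2, a step that the two limits leave unreadable from compound 1 to compound 3 and a step that the two limits leave unreadable from compound 2 to compound 3; what is known is only the limit of > 1000 nM in this assay, at which 2 of the 3 values shown sit, and (the limit of > 10000 nM in this assay, at which 1 of the 3 values shown sits).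

Compound 4 `COC(=O)c1ccc(NCc2cncn2Cc2ccc(C#N)cc2)cc1-c1ccccc1` differs from compound 1 by cyano in place of phenyl on an aromatic carbon. Among the compounds with values here, none of the three measured steps touches this part of the molecule, and none of them is readable in size, so there is no measured step from which a direction can be drawn. Within the data shown here, the series so far shows no cytotoxicity within the tested window.

For compound 4 the value in this assay is estimated at 3000 nM, with a range of 1000 nM to 30000 nM. The step this estimate implies is expected to be a step that the limit leaves unreadable from compound 1 to compound 4, most likely reported again as a limit.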

Compound 4, half-maximal effective concentration: > 10000 nM
Compound 4: no number, only a limit; the forecaster's own chance of this, stated with the estimate: 80%; at least 3.3-fold (0.52 log units) between middle value and limit.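

In this assay compound 4 gives > 10000 nM, which is a limit of the assay and not a number. Within the data shown here, compound 1 is likewise only a limit, and no step from compound 1 to compound 4 can be read. The compounds shown leave open at what concentration any of them produces cytotoxicity, and whether cyano in place of phenyl alters it.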